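The source may hold more compounds than are shown below. What is called first, only, known or untested is meant among the compounds shown, and "the series" means these compounds.

Measured so far in a physicochemical assay for solubility, read by LC-MS, in phosphate buffer, with a stated time of 24 h, at pH 7.4; on this read-out higher numbers stand for higher solubility and lower numbers for lower solubility:
compound 1 `Fc1ccc2c(c1CNc1ncc(Oc3ccccc3)c3nncn13)CCO2`: 8000 nM
compound 2 `COCCC(=O)Nc1cnc(NCc2c(F)ccc3c2CCO3)n2cnnc12`: 980000 nM

Compound 2 holds the higher of the two numbers, at 980000 nM. Compound 3 `CN(c1ccccc1)c1cnc(NCc2c(F)ccc3c2CCO3)n2cnnc12` is not yet measured and differs from it on the shared core: methyl(phenyl)amino in place of ((2-methoxyethyl)carbonyl)amino on an aromatic carbon. In words, methyl(phenyl)amino stands in place of ((2-methoxyethyl)carbonyl)amino on an aromatic carbon. For the measured compounds named here, one measured step bears on this, and it is large and beyond the scatter: a 120-fold higher number from compound 1 to compound 2 (2.09 log units; beyond the scatter). There, ((2-methoxyethyl)carbonyl)amino replaced phenoxy. Compound 3 gives up that group for another one with a six-membered aromatic ring of carbon only, so a large step in the opposite direction is expected in this assay, though on the evidence of one pair alone. The expected step is a 160-fold lower number from compound 2 to compound 3 (2.21 log units; beyond the scatter). The estimate for compound 3 is 6000 nM, with an expected range from 1500 nM to 25000 nM.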

Compound 3, solubility: < 2000 nM
Compound 3 ended at the assay's limit; the forecaster's own chance of this, stated with the estimate: 3%; middle value at least 3.0-fold (0.47 log units) from the limit.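

In this assay compound 3 gives < 2000 nM, which is a limit of the assay and not a number: the limit of < 2000 nM in this assay, at which 1 of the 3 values shown sits. Methyl(phenyl)amino in place of ((2-methoxyethyl)carbonyl)amino gives an at least 490-fold lower number from compound 2 to compound 3 (2.69 log units; beyond the scatter), so this position on an aromatic carbon has now moved the number strongly in both directions, and the high number of compound 2 does not carry over to a group with a six-membered aromatic ring of carbon only. The ring alone does not set the number, as methyl(phenyl)amino in place of phenoxy gives an at least 4.0-fold lower number from compound 1 to compound 3 (0.60 log units; beyond the scatter).

Going by these compounds, how far compound 3 lies past its limit remains unknown. Also open, on these data alone, is whether the amide hydrogen, the carbonyl or the methoxy end goes with the high number of compound 2, a question that a plain acetylamino group or a morpholine at this position would help to separate.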